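The compounds below may be only part of what the source reports. "The series", "measured", "known", "first", "only" and "open" are said of these compounds alone.

Working notes on the series. The shared core is that of compound 1 `CC(C)[C@@H]1CC[C@@H](C)C[C@@]12N(C)C(=O)[C@@H]1[C@H]3C(=O)NC(=O)[C@H]3ON12`, which in a functional assay, read by spectrophotometry, with a stated time of 2 h, tested at 2 mg/mL (on this read-out lower numbers stand for a weaker effect and higher numbers for a stronger effect at the one concentration tested), gives 57.2%. Among the measured compounds shown here, this is the highest of the three numbers measured so far. Compound 2 `CC(C)[C@@H]1CC[C@@H](C)C[C@@]12N(C)C(=O)[C@@H]1[C@H]3C(=O)N(c4ccccc4)C(=O)[C@H]3ON12` carries a phenyl on the ring amide nitrogen and gives 41% in this assay; compound 3 `Cc1cccc(N2C(=O)[C@H]3[C@H](ON4[C@@H]3C(=O)N(C)[C@@]43C[C@H](C)CC[C@H]3C(C)C)C2=O)c1` carries a 3-methylphenyl there and gives 35.3%.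

The step to be followed is from compound 1 to compound 4 `CC(C)[C@@H]1CC[C@@H](C)C[C@@]12N(C)C(=O)[C@@H]1[C@H]3C(=O)N(c4ccc5ccccc5c4)C(=O)[C@H]3ON12`: naphthalen-2-yl in place of hydrogen on an amide-type nitrogen in a ring. For the measured compounds named here, two measured steps bear on it directly, since both put an aromatic group onto the same nitrogen. The phenyl step gave a number 16.2 percentage points lower from compound 1 to compound 2 (beyond the scatter), and the 3-methylphenyl step gave a number 21.9 percentage points lower from compound 1 to compound 3 (beyond the scatter). The methyl on the aromatic carbon between those two compounds, a number 5.7 percentage points lower from compound 2 to compound 3 (within the scatter), made no difference beyond the scatter. Both aryl replacements of the amide hydrogen thus lowered the read-out by a modest amount, and a larger aromatic group in the same place is expected to behave in the same direction, at least as far as the phenyl and 3-methylphenyl did. Going by the values given here, no compound measured so far goes against this, but the pattern rests on two steps only.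

For compound 4 the expected step is therefore a number 24.2 percentage points lower from compound 1 to compound 4 (beyond the scatter), downward in this assay. Compound 4 is estimated at 33%, with a range from 20% to 47%.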

Compound 4, a percentage reported as activity, at one concentration (the size of the read-out at that concentration, not a potency): 43.6%
Compound 4: middle estimate off by 10.6 percentage points, on the low side; the range from low to high includes it.
By their numbers in this assay, from the lowest: compounds 3, 2 and 4 (each within the scatter of the next); then compound 1.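

With naphthalen-2-yl on the amide-type nitrogen the read-out in this assay gives a number 13.6 percentage points lower from compound 1 to compound 4 (beyond the scatter) and thus a third aryl replacement of the amide hydrogen lies below compound 1 by more than the scatter, with compounds 2, 3 and 4 all agreeing and none going against this. The size of the aromatic group, up to 10 heavy atoms and 2 aromatic rings, does not separate these compounds: the change gives a number 2.6 percentage points higher from compound 2 to compound 4 (within the scatter) and also a number 8.3 percentage points higher from compound 3 to compound 4 (within the scatter) so that at this position the three aryl groups cannot be told apart in this read-out, and the step from hydrogen to aryl is the only one beyond the scatter. No measurement at hand accounts for this flat response among the aryl groups.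

Still open, on these data alone, is whether a non-aromatic group on this nitrogen, such as a methyl or a longer alkyl chain, would stay nearer compound 1 or fall with the aryl compounds. Also open, as far as these compounds go, is whether an amine or a carboxylic acid on the phenyl ring would move the read-out away from the level shared by compounds 2, 3 and 4.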